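The compounds below may be only part of what the source reports. "The series", "measured", "known", "first", "only" and "open" are said of these compounds alone.

The measured compounds:
Compound 1, `NC1(CCn2ccc(=O)[nH]c2=O)OC(=O)C(OCc2ccccc2)=C1OCc1ccccc1`, gives > 100000 nM in a functional assay on MIA PaCa-2 cells (Homo sapiens) for inhibition, read by MTT assay, with a stated time of 72 h; a lower number here means a stronger inhibitor, a higher number a weaker inhibitor; this is a limit of the assay, not a number.
Compound 2, `O=C1O/C(=C\Cn2ccc(NC(=O)c3ccccc3)nc2=O)C(OCc2ccccc2)=C1OCc1ccccc1`, gives 24200 nM in this assay.
Compound 3, `O=C1O[C@H]([C@@H](O)Cn2c(=O)[nH]c(=O)[nH]c2=O)C(OCc2ccccc2)=C1OCc1ccccc1`, gives > 100000 nM in this assay; this too is a limit of the assay, not a number.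

Among the compounds with values here, compound 1 stands at the limit of > 100000 nM in this assay, at which 2 of the 3 values shown sit, so only a limit is known for it, and no step between measured compounds in this assay connects it to the others. Within the data shown here, compound 2 is the only one with a measured number. Compound 4, `Cc1cn(CCC2(N)OC(=O)C(OCc3ccccc3)=C2OCc2ccccc2)c(=O)[nH]c1=O`, has not yet been measured in this assay. It differs from compound 1 by methyl in place of hydrogen on an aromatic carbon. With compound 1 reporting only a limit, the step to compound 4 cannot be set against any measured change of this kind. Given the limit for compound 1 shown by the limit of > 100000 nM in this assay, at which 2 of the 3 values shown sit, compound 4 is expected to remain near that limit, with a step that the limit leaves unreadable from compound 1 to compound 4 that amounts to no change beyond the scatter. For compound 4 the estimate is 150000 nM, with a range from 50000 nM to 500000 nM, and most probably only a limit will again be reported.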

Compound 4, half-maximal inhibitory concentration: > 100000 nM
Compound 4 ended at the assay's limit; the forecaster's own chance of this, stated with the estimate: 80%; the middle value does not contradict the limit.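

Compound 1 and compound 4 both sit at a limit of the assay rather than at a number, so no step between them can be read: the limit of > 100000 nM in this assay, at which 3 of the 4 values shown sit.

In this assay the compounds shown leave open whether methyl in place of hydrogen on an aromatic carbon changes inhibition at all.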